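The source may report more compounds than this note shows. Statements on the series, on what has been measured and on what is new or still open speak of the compounds shown alone.

Within the data shown here, compound 2 `N=c1sc2cc(OC(F)(F)F)ccc2n1CCS` holds the lower of the two numbers measured so far in a functional assay on the whole organism with Rattus norvegicus as the target (on this read-out higher numbers stand for an effect only at larger amounts of compound and lower numbers for an effect already at smaller amounts), where compound 2 gives 2 mg/kg. Among the measured compounds shown here, its only neighbour, compound 1 `N=c1sc2cc(OC(F)(F)F)ccc2n1CCO`, gives 8 mg/kg in this assay, and the step of a 4.0-fold lower number from compound 1 to compound 2 (0.60 log units; beyond the scatter) is beyond the scatter. Compound 3 `CC[S+]([O-])CCn1c(=N)sc2cc(OC(F)(F)F)ccc21` differs from compound 2 as follows: a group of 4 heavy atoms (2 carbon, 1 oxygen, 1 sulfur; no ring) in place of one sulfur atom, on a saturated chain carbon, two bonds along the chain from an aromatic nitrogen. For the measured compounds named here, the one measured step, a 4.0-fold lower number from compound 1 to compound 2 (0.60 log units; beyond the scatter), occurs at the same saturated chain carbon, two bonds along the chain from an aromatic nitrogen, where a sulfanyl replaced a hydroxy. Going by the values given here, it is the only measured step that bears on the present change. The present change removes that sulfanyl, together with its hydrogen-bond donor, and puts in a group of two carbons, one oxygen and one sulfur with a single hydrogen-bond acceptor. Among the compounds with values here, no measured pair shows this kind of exchange, so the direction is uncertain; a step no larger than modest, and most likely back toward the number of compound 1, is expected. For compound 3 the estimate in this assay is 4 mg/kg, within 1.5 mg/kg to 12 mg/kg, which corresponds to an expected step of a 2.0-fold higher number from compound 2 to compound 3 (0.30 log units; within the scatter).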

Compound 3, dose for half-maximal effect: 1.2 mg/kg
Compound 3: middle estimate off by 3.3-fold (0.52 log units), on the high side, outside the stated range (below it).
By their numbers in this assay, from the lowest: compounds 3 and 2 (each within the scatter of the next); then compound 1.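

At the saturated chain carbon, two bonds along the chain from an aromatic nitrogen, replacing the sulfanyl with a group of 4 heavy atoms that has 0 hydrogen-bond donors gives a 1.7-fold lower number from compound 2 to compound 3 (0.22 log units; within the scatter) in this assay, so the number does not move back toward that of compound 1. Measured against the hydroxy compound, the same exchange gives a 6.7-fold lower number from compound 1 to compound 3 (0.82 log units; beyond the scatter), which places both sulfur-bearing chains apart from compound 1 and shows that, among these compounds, the low number does not depend on the hydrogen-bond donor of the sulfanyl. Nothing available here accounts for these numbers.

The compounds shown leave open whether the oxygen on sulfur in compound 3 or its ethyl group contributes to the result, a question that an ethylsulfanyl or an ethylsulfonyl group at this chain carbon could help to separate. They also leave open how far this position tolerates groups without sulfur, such as an amine or a carboxylic acid, and what a longer chain would do to the number.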